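Nitro for methyl on the aryl ring of a semicarbazone

The source may hold more compounds than are shown below. What is called first, only, known or untested is meant among the compounds shown, and "the series" means these compounds.

The series consists of three measured semicarbazones sharing a core carrying a chain ending in a carboxylic acid. Compound 1, `O=C(O)CCCNC(=O)N/N=C/c1ccc(Cl)cc1`, gives 68% in a functional assay on the whole organism (strain Swiss Albino) for inhibition, with Mus musculus as the target, in the writhing test, at a dose of 100 mg/kg by the intraperitoneal route; a higher number here means more inhibition at the dose given (going by the name of the read-out), a lower number less inhibition. Compound 2, `C/C(=N\NC(=O)NCCCC(=O)O)c1ccccc1`, gives 82% in this assay, and compound 3, `C/C(=N\NC(=O)NCCCC(=O)O)c1ccc(C)cc1`, gives 82%. Compound 3 therefore stands level with compound 2 at the digits shown, the two together being the highest of the three numbers, while compound 1 sits below them by a gap beyond the scatter. Among the compounds with values here, the one single-site step available, no change at the digits printed from compound 2 to compound 3 (within the scatter), lies within the scatter.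

The next compound, compound 4, `C/C(=N\NC(=O)NCCCC(=O)O)c1ccc([N+](=O)[O-])cc1`, differs from compound 3 as nitro in place of methyl on an aromatic carbon. Within the data shown here, no measured step exchanges a methyl for a nitro group, so the only step that bears on the change is the one from compound 2 to compound 3, which shows that an alteration at this position of the ring left this assay essentially unchanged. On that basis compound 4 is expected to show a step of about a number 4 percentage points lower from compound 3 to compound 4 (within the scatter), that is, no change beyond the scatter. Compound 4 is accordingly estimated at 78%, with a range from 64% to 90%.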

Compound 4, a percentage reported as inhibition, in the whole organism at one dose (the size of the read-out at that dose, not a potency): 67%
For compound 4 the middle estimate is 11 percentage points above the measured one; measured number inside the range.
By their numbers in this assay, from the lowest: compounds 4 and 1 (each within the scatter of the next); then compounds 2 and 3 (each within the scatter of the next).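

With nitro in place of methyl on this aromatic carbon, this assay gives a number 15 percentage points lower from compound 3 to compound 4 (beyond the scatter), and with nitro in place of hydrogen it gives a number 15 percentage points lower from compound 2 to compound 4 (beyond the scatter). Within the data shown here, the only earlier step at this position, no change at the digits printed from compound 2 to compound 3 (within the scatter), showed that methyl could replace hydrogen without a change beyond the scatter, whereas these two steps show that the position is not indifferent to every group placed there, since nitro gives a lower number than either hydrogen or methyl. The data at hand hold no measurement that bears on this difference between nitro and the two smaller substituents.

The compounds shown leave open how other groups on this aromatic carbon, such as an amine, a methoxy group or a nitrile, would read in this assay, and so whether the lower number is peculiar to nitro or extends to other replacements. They also leave open whether a longer chain, or an ester in place of the carboxylic acid, would change the number when nitro is present on the ring.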